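Hydroxy removal from compound 1: expected loss of growth inhibition

A few compounds are considered here, and "the series" means these few. Any claim that something is new, unique, unknown or untested is made for them only; others in the source may bear on it.

In a functional assay on NCI-H460 cells (Homo sapiens) for inhibition, read by sulforhodamine B assay, with a stated time of 48 h (on this read-out higher numbers stand for weaker inhibition of growth and lower numbers for stronger inhibition of growth), compound 1 `COc1ccc2c(c1O)CCCC=C2c1cc(OC)c(OC)c(OC)c1` gives 0.028 nM and has the lowest number of the three measured compounds. Compound 3 `COc1ccc2c(c1)CCCC(c1cc(OC)c(OC)c(OC)c1)=C2` comes nearest with 470 nM as its value, and compound 2 `COc1ccc(C(=O)C2=CCCc3c2cc(OC)c(OC)c3OC)c(O)c1O` lies furthest with 2800 nM as its value. Both gaps from compound 1 lie beyond the scatter.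

Compound 4 `COc1ccc2c(c1)CCCC=C2c1cc(OC)c(OC)c(OC)c1` departs from compound 1 by one change hydrogen in place of hydroxy on an aromatic carbon with hydrogen in place of hydroxy on an aromatic carbon, ortho to a methoxy group. Going by the values given here, no measured pair isolates this change, so its size has to be judged indirectly. Compound 3 also has no hydroxy group and gives 470 nM in this assay as its number. Compound 2 goes against any simple reading, since it carries hydroxy groups and still gives 2800 nM as the highest number of the three.

A large rise in the number, well beyond the scatter, is therefore expected, with compound 3 at 470 nM as the nearest reference without a hydroxy group. The expected step of a 1100-fold higher number from compound 1 to compound 4 (3.03 log units; beyond the scatter) points towards weaker inhibition of growth. For compound 4 the estimated value is 30 nM with an expected range from 3 nM to 300 nM on repeat measurement.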

Compound 4, concentration for 50% growth inhibition: 51 nM
For compound 4 the middle estimate is 1.7-fold (0.23 log units) below the measured one; measured number inside the range.
By their numbers in this assay, from the lowest: compound 1; then compound 4; then compound 3; then compound 2.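

In this assay, going by these compounds alone, the hydroxy group on the aromatic carbon ortho to a methoxy group now has a directly measured contribution: replacing it with hydrogen gives a 1800-fold higher number from compound 1 to compound 4 (3.26 log units; beyond the scatter), the first step that isolates a single change. The pair therefore ties the very low number of compound 1 to this one position on the shared core. The earlier compounds shown here could not establish this link. None of them formed a matched pair with compound 1. Nothing available explains why this single replacement carries so large a step, so the result stands as a description of the change only.

Still open, as far as these compounds go, is whether the step requires a hydroxy group specifically, or whether an amino group, a fluorine atom or a methoxy group on the same aromatic carbon would keep part of the growth inhibition. Also open, from the compounds shown here alone, is whether a hydroxy group at the corresponding place on the core of compound 3 would give a step of similar size.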